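Amide N-Methylation Across Two Cores in a Lipophilicity Series

A few compounds are considered here, and "the series" means these few. Any claim that something is new, unique, unknown or untested is made for them only; others in the source may bear on it.

Of the compounds shown here, three have been measured in a physicochemical assay for lipophilicity, using the shake flask method, in phosphate buffer, measured as octanol-water partition, with a stated time of 30 min, at pH 7.4; on this read-out lower numbers stand for lower lipophilicity and higher numbers for higher lipophilicity. Compound 2 `CNC(=O)c1cc(-c2cnc(NCc3c(F)ccc4c3CCO4)c3cn[nH]c(=O)c23)n(C)n1` gives 2.1, and compound 1 `CN(C)C(=O)c1cc(-c2cnc(NCc3c(F)ccc4c3CCO4)c3cn[nH]c(=O)c23)n(C)n1` gives 2.1. The two differ by methyl in place of hydrogen on an amide-type nitrogen, and the result was no change at the digits printed from compound 2 to compound 1 (within the scatter). Compound 3 `CNC(=O)c1ccc(-c2cnc(NCc3c(F)ccc4c3CCO4)c3cn[nH]c(=O)c23)c(C)n1` carries a different core; how it differs from compound 2 is described by 2-methyl-6-(methylcarbamoyl)pyridin-3-yl in place of 1-methyl-3-(methylcarbamoyl)-1H-pyrazol-5-yl on an aromatic carbon, and in this assay compound 3 gives 2.9, which is a number 0.80 log units higher from compound 2 to compound 3 (beyond the scatter) and likewise a number 0.80 log units higher from compound 1 to compound 3 (beyond the scatter), so that compound 3 stands highest of the three.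

Compound 4 `Cc1nc(C(=O)N(C)C)ccc1-c1cnc(NCc2c(F)ccc3c2CCO3)c2cn[nH]c(=O)c12` has not yet been measured. It differs from compound 3 by methyl in place of hydrogen on an amide-type nitrogen. The place of the change is described in the same words as the place of the change from compound 2 to compound 1, so the change itself is the same, only carried out on the core of compound 3 rather than on the core of compound 2. Within the data shown here, since the earlier step was no change at the digits printed from compound 2 to compound 1 (within the scatter), the expectation for compound 4 rests on that single precedent, with the caveat that the core is different and the pair from compound 2 to compound 1 is the only example available. The step expected from compound 3 to compound 4 is therefore a number 0.05 log units higher from compound 3 to compound 4 (within the scatter). On that basis compound 4 is estimated to give 2.95 in this assay, with a range expected between 2.6 and 3.3.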

Compound 4, distribution coefficient: 2.1
Compound 4: the middle estimate sits 0.85 log units above what was measured; the whole stated range lies above it.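

In this assay, the same change, methyl in place of hydrogen on an amide-type nitrogen, gave no change at the digits printed from compound 2 to compound 1 (within the scatter) on one core but a number 0.80 log units lower from compound 3 to compound 4 (beyond the scatter) on the other, so among these compounds the result seen on the first core did not carry over to the second. With the dimethylcarbamoyl group in place, compound 1 gives 2.1 and compound 4 gives 2.1, the same printed value on both cores, but this rests on a single pair for each core and does not show how the change would behave on any further core or whether the contrast would hold on repeated measurement. Nothing here accounts for why the two steps differ.

The compounds shown leave open how the read-out would respond on each core if the amide nitrogen carried two hydrogens, as in a primary carboxamide, or an ethyl group in place of the added methyl. They also leave open whether a pyrrolidine amide, with the nitrogen held within a ring, would follow the step seen on the core of compound 2 or the one seen on the core of compound 3.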